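A few compounds are considered here, and "the series" means these few. Any claim that something is new, unique, unknown or untested is made for them only; others in the source may bear on it.

Measured compounds in a functional assay on K562 cells (Homo sapiens) for antiproliferative activity, read by CCK-8 assay, with a stated time of 72 h; on this read-out higher numbers stand for weaker inhibition of growth and lower numbers for stronger inhibition of growth:
compound 1 `CC[C@@H]1C(=O)N(C)c2cnc(Nc3ccc(S(=O)(=O)NCCO)cc3)nc2N1C1CCCC1` — 546 nM
compound 2 `CCC1C(=O)N(C)c2cnc(Nc3ccc(S(=O)(=O)NCCO)cc3)nc2N1c1ccn(C)n1` — "not active" (no number reported)
compound 3 `CCC1C(=O)N(C)c2cnc(-n3ccc4cc(C(=O)NC(C)C)ccc43)nc2N1c1ccn(C)n1` — 8910 nM

Among the numbers reported, compound 1 stands lowest. Going by the values given here, compound 3 gives the only other number, and its value lies well above that of compound 1, a gap beyond the scatter of this assay. Compound 2 is reported as not active without a number, so no comparison by size can be made with it.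

Compound 4 `CC[C@@H]1C(=O)N(C)c2cnc(Nc3ccc(S(=O)(=O)Nc4ccccc4)cc3)nc2N1C1CCCC1` has not yet been measured. It differs from compound 1 in one place: phenyl in place of 2-hydroxyethyl on a sulfonamide nitrogen. Among the compounds with values here, no measured pair shows this change, so its effect on the read-out has to be guessed. Because compound 1 gives 546 nM and the shared core is kept intact, the account expects the step of a 1.1-fold higher number from compound 1 to compound 4 (0.04 log units; within the scatter) to be small, in no firm direction, and quite possibly within the scatter. Compound 4 is therefore expected to give about 600 nM, with a plausible range from 150 nM to 2500 nM.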

Compound 4, concentration for 50% growth inhibition: 4180 nM
Estimate against measurement, compound 4: 7.0-fold (0.84 log units) below; the whole stated range lies below it.
By their numbers in this assay, from the lowest: compound 1; then compound 4; then compound 3.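

In this assay, the sulfonamide nitrogen proves sensitive to what it carries: phenyl in place of 2-hydroxyethyl, with the rest of compound 1 kept, gives a 7.7-fold higher number from compound 1 to compound 4 (0.88 log units; beyond the scatter) on this single pair. Going by these compounds alone, the earlier compounds held no pair differing in one place, so this is the first measured step of any kind in the set, and it shows that this position is not indifferent to the change. No measurement shown bears on why the step occurs.

The pair does not separate the loss of the 2-hydroxyethyl group from the arrival of the phenyl ring. A plain ethyl group, a longer hydroxyalkyl chain, a terminal amine or a carboxylic acid on this nitrogen would each test a different part of that question, and the compounds shown leave all of these open.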